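This account rests on a few compounds, and the source may have more. Where it says the series, first, only, none or still open, it means among the compounds named here.

Of the compounds shown here, two with a shared core have been measured so far in a physicochemical assay for lipophilicity (on this read-out lower numbers stand for lower lipophilicity and higher numbers for higher lipophilicity), and both carry a phenyl group on the same ring carbon. Compound 1 `C[C@H]1CC[C@@H]2[C@@H](OC(=O)[C@]23CC(c2ccc(C#N)cc2)N(c2ccccc2)O3)[C@]2(C)C(=O)C=C[C@@]12O` gives 2.94 as its value. Compound 2 `Cc1ccccc1C1C[C@@]2(ON1c1ccccc1)C(=O)O[C@@H]1[C@H]2CC[C@H](C)[C@]2(O)C=CC(=O)[C@@]12C` gives 3.64 as the higher of the two numbers. Compound 3 `C[C@H]1CC[C@@H]2[C@@H](OC(=O)[C@]23CC(c2cccc(Cl)c2)N(c2ccccc2)O3)[C@]2(C)C(=O)C=C[C@@]12O` comes next, and the change from compound 2 is 3-chlorophenyl in place of 2-methylphenyl on a saturated ring carbon and amounts to 3-chlorophenyl in place of 2-methylphenyl on a saturated ring carbon. Among the measured compounds shown here, one measured step bears on this, namely a number 0.70 log units higher from compound 1 to compound 2 (beyond the scatter) where 4-cyanophenyl gave way to 2-methylphenyl. For the measured compounds named here, no measured compound carries 3-chlorophenyl, and that step gives no direction for this swap. Taking compound 2 at 3.64 as the reference, no step beyond the scatter is expected in this assay for this change. The expected step is a number 0.01 log units higher from compound 2 to compound 3 (within the scatter) and remains an estimate. For compound 3 the estimated value is 3.65 with a range from 3.25 to 4.05 on this scale.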

Compound 3, partition coefficient: 3.87
Estimate against measurement, compound 3: 0.22 log units below; low and high end bracket the measured number.
By their numbers in this assay, from the lowest: compound 1; then compounds 2 and 3 (each within the scatter of the next).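

In this assay, the swap at this saturated ring carbon gives a number 0.23 log units higher from compound 2 to compound 3 (within the scatter), so 3-chlorophenyl and 2-methylphenyl cannot be told apart on this read-out. Replacing 4-cyanophenyl with 3-chlorophenyl gives a number 0.93 log units higher from compound 1 to compound 3 (beyond the scatter), which means that 4-cyanophenyl now stands apart from two different groups at this position, not just from one. Nothing measured explains these numbers.

Going by these compounds, all three compounds carry a substituted phenyl group at this carbon, so it remains open how an amine or a carboxylic acid on that phenyl, or a longer chain in its place, would read. Compound 2 and compound 3 also differ both in the added group and in where it sits on the phenyl, so these two changes cannot be separated.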